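Swapping one aromatic ring for another in a stable amine

The source may report more compounds than this note shows. Statements on the series, on what has been measured and on what is new or still open speak of the compounds shown alone.

Compound 3 `c1ccc2c(c1)CN[C@H](CN(CCCN1CCNCC1)[C@H]1CCCc3cccnc31)C2` is one of three related amines tested in an ADME assay on microsomes from liver (Homo sapiens) for metabolic stability, read by LC-MS, with a stated time of 10 min, tested at 0.5 uM; a higher number here means that more of the compound is left, a lower number that less of the compound is left. Compound 3 gives 99%; compound 2 `c1ccc2c(c1)CN[C@@H](CN(CC[C@H]1CCCNC1)[C@H]1CCCc3cccnc31)C2` gives 93%, within the scatter of that number, while compound 1 `CN1CCN(CCCN(C[C@H]2Cc3ccccc3CN2)[C@H]2CCCc3cccnc32)CC1` gives 72%, well below both. For the measured compounds named here, the only measured step, a number 21 percentage points higher from compound 1 to compound 2 (beyond the scatter), alters a different part of the molecule. Compound 4 `c1cnc2c(c1)CN[C@H](CN(CCCN1CCNCC1)[C@H]1CCCc3cccnc31)C2` differs from compound 3 as follows: a group of 10 heavy atoms (8 carbon, 2 nitrogen; one six-membered non-aromatic ring with 1 hetero atom, one six-membered aromatic ring with 1 hetero atom) in place of a group of 10 heavy atoms (9 carbon, 1 nitrogen; one six-membered non-aromatic ring with 1 hetero atom, one six-membered aromatic ring of carbon only), on a saturated chain carbon bound to an amine nitrogen. Going by the values given here, no measured step touches this position, so the expectation rests on compound 3 alone. Compound 4 is expected to stay near the top of the range, with a number 5 percentage points lower from compound 3 to compound 4 (within the scatter) in this assay. The estimate for compound 4 is 94%, between 80% and 100%.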

Compound 4, percent of the compound remaining: 100%
The estimate for compound 4 lay 6 percentage points below the measured number, and the stated range covers the measured number.
By their numbers in this assay, from the lowest: compound 1; then compounds 2, 3 and 4 (each within the scatter of the next).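

In this assay, the result is a number 1 percentage points higher from compound 3 to compound 4 (within the scatter), so this position accepts an aromatic ring with one hetero atom in place of the carbon-only ring without any change beyond the scatter. Both compounds sit so close to the top of the scale that this swap has little room to show a gain here. Nothing available explains the result.

Still open, on these data alone, is whether the same swap would matter on the core of compound 1, which gives 72% and has more room to move. A fluorine or methoxy group on this aromatic ring also remains untested among these compounds.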